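A swap of the aryl group on the ring nitrogen

The source may report more compounds than this note shows. Statements on the series, on what has been measured and on what is new or still open speak of the compounds shown alone.

Of the compounds shown here, two built on the same core have been measured in a functional assay on CHO cells with adenosine receptor A1 (Homo sapiens) as the target, read by cAMP accumulation and immunoassay, with a stated time of 6 min, tested at 0.1 uM; a lower number here means a stronger effect, a higher number a weaker effect of the compound at the concentration tested. Compound 1, with the structure `Nc1scc(CN2CCN(c3ccc(OC(F)(F)F)cc3)CC2)c1C(=O)c1ccc(Cl)cc1`, gives -13% in this assay. Compound 2, with the structure `Nc1scc(CN2CCC(c3ccc(Cl)cc3)CC2)c1C(=O)c1ccc(Cl)cc1`, gives -2.3%. Compound 1 thus has the lowest of the two numbers, and the gap to compound 2 is beyond the usual scatter, so compound 1 shows the stronger effect of the two at the tested concentration.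

Compound 3, with the structure `Nc1scc(CN2CCN(c3cc(F)ccc3F)CC2)c1C(=O)c1ccc(Cl)cc1`, has not yet been measured. It differs from compound 1 in one place: 2,5-difluorophenyl in place of 4-(trifluoromethoxy)phenyl on an amine nitrogen in a ring. The leaving group carries one hydrogen-bond acceptor, the entering group none, and the entering group is smaller, as the counts show.

Among the compounds with values here, no measured pair tells how this particular change plays out, so the expectation rests on compound 1 alone. Both measured numbers sit close to zero, and a modest step toward a weaker effect, within or near the scatter, is the expected outcome, giving an expected step of a number 6 percentage points higher from compound 1 to compound 3 (within the scatter). Compound 3 is therefore estimated at -7%, with a plausible range from -25% to 10%.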

Compound 3, a percentage reported as activity, at one concentration (the size of the read-out at that concentration, not a potency): -13%
Estimate against measurement, compound 3: 6 percentage points above, and the stated range covers the measured number.
By their numbers in this assay, from the lowest: compounds 1 and 3 (each within the scatter of the next); then compound 2.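

In this assay, placing 2,5-difluorophenyl in place of 4-(trifluoromethoxy)phenyl on the amine nitrogen in the ring gives no change at the digits printed from compound 1 to compound 3 (within the scatter), the only direct reading of a change at this position among the compounds shown. At the single concentration tested, the read-out therefore holds when the aryl group on this nitrogen becomes smaller, loses its hydrogen-bond acceptor and carries two fluorines on the ring instead of a trifluoromethoxy group. No measurement shown here explains why these two aryl groups give the same reading.

Within the data shown here, the comparison covers only two aryl groups, both with fluorine, so it remains open whether an aryl group with an amine, or a methyl group or longer chain in place of the aryl group, would also leave the read-out unchanged. Because each compound was read at one concentration, the matching values of compound 1 and compound 3 also leave open whether the two would match across a range of concentrations.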